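A few compounds are considered here, and "the series" means these few. Any claim that something is new, unique, unknown or untested is made for them only; others in the source may bear on it.

Compound 1, `CCCCCCCCCCCCCCCCCCNC(=O)[C@H]1CSC(Cc2ccccc2)N1`, was tested in a functional assay on LNCaP cells (Prostate gland, Homo sapiens) for antiproliferative activity, read by sulforhodamine B assay (on this read-out lower numbers stand for stronger inhibition and higher numbers for weaker inhibition), where compound 1 gives 4400 nM. Among the two numbers recorded so far this is the highest; its nearest neighbour is compound 2, `CCCCCCCCCCCCCCCCCCNC(=O)[C@H]1CSC(c2cccnc2)N1`, which in this assay gives 3600 nM. Going by the values given here, the one measured step, a 1.2-fold lower number from compound 1 to compound 2 (0.09 log units; within the scatter), changes the group on the saturated ring carbon and stays within the scatter.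

The next compound, compound 3, `CCCCCCCCCCCCCCCCCCNC(=O)[C@H]1CSC(c2c(Cl)cccc2Cl)N1`, differs from compound 1 by 2,6-dichlorophenyl in place of benzyl on a saturated ring carbon. Among the compounds with values here, the only step that bears on this change is the one from compound 1 to compound 2, which also exchanged the benzyl group on the saturated ring carbon for an aromatic ring and produced no change beyond the scatter. Nothing in the data shows that an exchange at this position moves the number markedly in either direction. The author therefore expects compound 3 to show a step of a 1.1-fold lower number from compound 1 to compound 3 (0.04 log units; within the scatter), no larger than the scatter. For compound 3 the estimated value in this assay is 4000 nM, with a range from 1500 nM to 11000 nM.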

Compound 3, half-maximal inhibitory concentration: 13100 nM
Beside the measured number, compound 3's estimate is 3.3-fold (0.52 log units) below it; the whole stated range lies below it.
By their numbers in this assay, from the lowest: compounds 2 and 1 (each within the scatter of the next); then compound 3.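

Up to this point, the only exchange on the saturated ring carbon had stayed within the scatter, so the position could have seemed insensitive to the group it carries. In this assay, 2,6-dichlorophenyl gives a 3.0-fold higher number from compound 1 to compound 3 (0.47 log units; beyond the scatter) and a 3.6-fold higher number from compound 2 to compound 3 (0.56 log units; beyond the scatter) in turn, which shows that this position, next to the ring nitrogen and next to the ring sulfur, does respond to the group placed there, though only modestly, and that the response runs towards weaker inhibition, with compound 3 the weakest of the three. An aromatic ring on this carbon therefore does not by itself settle the outcome, since pyridin-3-yl and 2,6-dichlorophenyl part company here, and nothing available accounts for the shift.

The compounds shown leave open whether the loss follows from the two chlorine atoms together, since a plain phenyl group or a phenyl ring carrying a single chlorine would separate the chlorine atoms from the ring itself. They also leave open whether a hydroxyl or an amine on that ring would move the number the other way, towards stronger inhibition in this series.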